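Working notes on permeability: difluoromethyl to trifluoromethyl

The source may hold more compounds than are shown below. What is called first, only, known or untested is meant among the compounds shown, and "the series" means these compounds.

Measured so far:
Compound 1 `CC(C)COc1ncc(-c2cn(C)c3cc(C(=O)NS(C)(=O)=O)ccc23)cc1Cl` gives 443 nm/s in an ADME assay for permeability, using PAMPA, at pH 5.5; on this read-out higher numbers stand for higher permeability and lower numbers for lower permeability.
Compound 2 `Cn1cc(-c2ccc(C(F)F)cc2)c2cc(F)c(C(=O)NS(=O)(=O)C3CC3)cc21` gives 325 nm/s in this assay.

Compound 2 stands lowest of the two numbers shown, but its nearest neighbour, compound 1, lies within the usual scatter of the measurement, so no order between the two is claimed. Compound 3 `Cn1cc(-c2ccc(C(F)(F)F)cc2)c2cc(F)c(C(=O)NS(=O)(=O)C3CC3)cc21` has not been measured in this assay. It differs from compound 2 in one place: fluoro in place of hydrogen on a saturated chain carbon bound to an aromatic carbon and two fluorine atoms. Going by the values given here, no measured pair in this set carries the same change, so no step of known size is available for comparison, and the two measured compounds differ from each other in more than one place.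

The change adds a single fluorine on a saturated chain carbon already bound to two fluorine atoms, with no change in ring count, donor count or charge. For this assay the expected step of a 1.2-fold higher number from compound 2 to compound 3 (0.07 log units; within the scatter) is small, at most at the edge of the scatter, and more likely upward than downward. The estimate for compound 3 is 380 nm/s, with a range of 200 nm/s to 700 nm/s.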

Compound 3, apparent permeability: 1660 nm/s
Compound 3: the middle estimate sits 4.4-fold (0.64 log units) below what was measured; measured number outside the range, above it.
By their numbers in this assay, from the lowest: compounds 2 and 1 (each within the scatter of the next); then compound 3.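

In this assay, replacing hydrogen with fluoro on the saturated chain carbon bound to an aromatic carbon and two fluorine atoms gives a 5.1-fold higher number from compound 2 to compound 3 (0.71 log units; beyond the scatter). Going by these compounds alone, this is the first step of known size, and it shows that this place is not silent on this read-out. The entering group is one heavy atom, with no ring, no hydrogen-bond donor or acceptor and no net charge, and the rest of the structure stays the same between the two compounds. Nothing at hand bears on the reason for the size of this step.

The finding rests on a single pair, so the compounds shown leave open whether the same change gives a step of similar size on another core, including the core of compound 1, which differs from compound 2 in more than one place. They also leave open how the read-out behaves with other groups at this place, such as monofluoromethyl, which would show how the number runs with fluorine count, or a nitrile, which carries no fluorine at all.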